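From methyl to fluoro in compound 3

The source may hold more compounds than are shown below. What is called first, only, known or untested is meant among the compounds shown, and "the series" means these compounds.

Measured so far in a functional assay on NCI-H520 cells (Homo sapiens) for cytotoxicity; on this read-out higher numbers stand for weaker inhibition of growth and lower numbers for stronger inhibition of growth:
- compound 1 `COc1ccc(C2=C(c3ccc(SC)cc3)CC3CCCN3C2=O)cc1O` gives 6000 nM
- compound 2 `CSc1ccc(C2=C(c3ccc(C)c(C)c3)C(=O)N3CCCC3C2)cc1` gives 300 nM

Going by the values given here, of these two numbers, compound 2 holds the lower (300 nM), and compound 1 is its only neighbour. Among the compounds with values here, the one measured step, a 20-fold lower number from compound 1 to compound 2 (1.30 log units; beyond the scatter), came from putting 3,4-dimethylphenyl in place of 3-hydroxy-4-methoxyphenyl on a double-bonded ring carbon.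

Compound 3 `CSc1ccc(C2=C(c3ccc(F)c(C)c3)C(=O)N3CCCC3C2)cc1` keeps the core of compound 2 and alters that same phenyl group: fluoro in place of methyl on an aromatic carbon. This is fluoro in place of methyl on an aromatic carbon, ortho to a methyl group and para to a large group, so 3,4-dimethylphenyl becomes 4-fluoro-3-methylphenyl.

The step to compound 2 (a 20-fold lower number from compound 1 to compound 2 (1.30 log units; beyond the scatter)) shows that this group can shift the number in this assay strongly, but it exchanged a whole substituted phenyl group. Within the data shown here, no measured pair swaps methyl for fluoro, so the evidence is thin. A much smaller change is expected here, perhaps slightly upward, and possibly nothing beyond the scatter. The estimated step is a 1.3-fold higher number from compound 2 to compound 3 (0.12 log units; within the scatter), with a wide margin. Compound 3 is expected at 400 nM (estimated range 130 nM to 1200 nM).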

Compound 3, concentration for 50% growth inhibition: 500 nM
Beside the measured number, compound 3's estimate is 1.3-fold (0.10 log units) below it; measured number inside the range.
By their numbers in this assay, from the lowest: compounds 2 and 3 (each within the scatter of the next); then compound 1.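

Putting fluoro in place of methyl on this aromatic carbon in this assay reads as a 1.7-fold higher number from compound 2 to compound 3 (0.22 log units; within the scatter) and so does not separate the two compounds, which shows that this single-atom exchange can be made without a change that rises above the usual spread of repeated measurements. The large distance from the 3-hydroxy-4-methoxyphenyl compound also remains, as a 12-fold lower number from compound 1 to compound 3 (1.08 log units; beyond the scatter) shows, so in this small set it is not tied to 3,4-dimethylphenyl alone and also appears with 4-fluoro-3-methylphenyl. Nothing measured here offers an explanation for the similar numbers of these two groups.

Going by these compounds, what remains open is how this carbon responds to groups of a different kind, such as an amine, a carboxylic acid or a longer chain like propyl, since methyl and fluoro are each only one heavy atom. The compounds shown also leave unresolved what the methyl group kept in both compound 2 and compound 3 contributes, and whether replacing it with a chloro or methoxy group would shift the number beyond the scatter.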